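Trifluoromethylsulfonyl for ethylsulfonyl: a second look

The source may report more compounds than this note shows. Statements on the series, on what has been measured and on what is new or still open speak of the compounds shown alone.

Measured compounds:
compound 1, `CCS(=O)(=O)Nc1ccc(NC(=O)c2ccc(Cl)c([N+](=O)[O-])c2)cc1Cl`, 125000 nM
compound 2, `O=C(Nc1ccc(NS(=O)(=O)C(F)(F)F)c(Cl)c1)c1ccc(Cl)c([N+](=O)[O-])c1`, 31700 nM
compound 3, `CCS(=O)(=O)Nc1ccc(NC(=O)c2ccc(Cl)cc2)cc1F`, 152000 nM

Of the compounds shown here, three have been measured in an ADME assay on RAW264.7 cells (Mus musculus) for cytotoxicity, read by MTT assay, with a stated time of 48 h; on this read-out lower numbers stand for stronger inhibition and higher numbers for weaker inhibition. Compound 1 and compound 3 share an ethylsulfonyl group but differ in their cores; how the core of compound 1 differs from the core of compound 3 is not broken down here. In this assay compound 1 gives 125000 nM and compound 3 gives 152000 nM, two numbers that lie within the usual scatter of each other.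

Compound 2 differs from compound 1 in one place: trifluoromethyl in place of ethyl on a sulfonyl sulfur. This gave a 3.9-fold lower number from compound 1 to compound 2 (0.60 log units; beyond the scatter).

Compound 4, `O=C(Nc1ccc(NS(=O)(=O)C(F)(F)F)c(F)c1)c1ccc(Cl)cc1`, has not yet been measured. It stands to compound 3 as compound 2 stands to compound 1: trifluoromethyl in place of ethyl on a sulfonyl sulfur. The place of the change is the same in both pairs, so this is the same change, made on a different core.

Among the measured compounds shown here, since the only measured instance of this change is a 3.9-fold lower number from compound 1 to compound 2 (0.60 log units; beyond the scatter), and, starting close to compound 1, compound 3 gives 152000 nM, the step expected from compound 3 to compound 4 in this assay is a 3.9-fold lower number from compound 3 to compound 4 (0.59 log units; beyond the scatter), of about the size seen before, though a single earlier example is a thin basis. Compound 4 is therefore estimated at 39000 nM, with a range from 15000 nM to 100000 nM.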

Compound 4, half-maximal inhibitory concentration: 3270 nM
Estimate against measurement, compound 4: 12-fold (1.08 log units) above; the measured number lies below the stated range.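

In this assay, trifluoromethyl in place of ethyl on a sulfonyl sulfur again went with a lower number, this time a 46-fold lower number from compound 3 to compound 4 (1.67 log units; beyond the scatter), so on these two cores the direction of the change is the same. The size of the step did not carry over from one core to the other, and the two steps stand well apart: the same change on two cores in this assay, a 3.9-fold lower number (0.60 log units; beyond the scatter) from compound 1 to compound 2 and a 46-fold lower number (1.67 log units; beyond the scatter) from compound 3 to compound 4, 12-fold (1.07 log units) apart, beyond the scatter of two such steps. This shows that the direction held in both pairs but that the step seen on one core was a poor guide to its size on the other; it does not show which difference between the core of compound 1 and the core of compound 3 goes with the larger step, nor how the change would behave on a third core.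

The compounds shown leave open which part of the core sets the size of the step, a question that would need cores differing from each other in one place only. They also leave open how a longer chain such as propyl, or a simple amine, would read in this assay when set on the same sulfonyl sulfur in place of ethyl or trifluoromethyl.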